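Alkoxyalkyl in place of alkyl on the core nitrogen

The compounds below may be only part of what the source reports. "The series", "measured", "known", "first", "only" and "open" are said of these compounds alone.

Among the compounds with values here, compound 1 `CCCCCCCn1c(N2CCN(C)CC2)nc2ccccc21` has the highest number of the two measured members: in a functional assay on ileum for inhibition of histamine H1 receptor (Cavia porcellus) (a higher number here means a weaker inhibitor, a lower number a stronger inhibitor), compound 1 gives 150 nM, while compound 2 `CCOCCn1c(N2CCCN(Cc3ccccc3)CC2)nc2ccccc21` gives 15 nM, a lower number beyond the scatter, though compound 2 differs in more than one place. Compound 3 `CCCCOCCn1c(N2CCN(C)CC2)nc2ccccc21` is the unmeasured analogue, with butoxy in place of pentyl on a saturated chain carbon, two bonds along the chain from an aromatic nitrogen. Within the data shown here, no single-point step of this kind has been measured. A modest move toward a lower number is expected, from compound 1 to compound 3 of a 1.9-fold lower number from compound 1 to compound 3 (0.27 log units; within the scatter). Compound 3 is therefore estimated at 80 nM, with a range from 25 nM to 250 nM.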

Compound 3, half-maximal inhibitory concentration: 38 nM
Compound 3: middle estimate off by 2.1-fold (0.32 log units), on the high side, within the range that was stated.
By their numbers in this assay, from the lowest: compound 2; then compound 3; then compound 1.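

Butoxy in place of pentyl, on a saturated chain carbon, two bonds along the chain from an aromatic nitrogen, gives a 3.9-fold lower number from compound 1 to compound 3 (0.60 log units; beyond the scatter) in this assay and is beyond the scatter. Unlike the gap between compound 1 and compound 2, this step belongs to a single change, so the ether oxygen alone moves the number at this position. Nothing measured accounts for the step.
Still open, on these data alone, is whether the oxygen's place along the chain matters. A longer alkoxy chain or a terminal amine on this chain also remains to be compared.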